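Chloro to Methyl on the Shared Core

The source may report more compounds than this note shows. Statements on the series, on what has been measured and on what is new or still open speak of the compounds shown alone.

Measured so far in an assay on isolated protein for displacement of a labelled ligand from metabotropic glutamate receptor 5 (Homo sapiens), with a stated time of 60 min, tested at 1 uM; on this read-out higher numbers stand for more inhibition at the one concentration tested (going by the name of the read-out) and lower numbers for less inhibition:
compound 1 `Cc1ccc(S(=O)(=O)c2cnc3ccc(Cl)cc3c2N2CCC(C)CC2)cc1` gives 95%
compound 2 `CC1CCN(c2c(S(=O)(=O)c3cccc(F)c3)cnc3ccc(Cl)cc23)CC1` gives 58%
compound 3 `Cc1ccc(S(=O)(=O)c2cnc3ccc(Cl)cc3c2N2CCC(C)CC2)cc1F` gives 68%

Compound 3 stands second highest of these three numbers. Its nearest neighbour is compound 2, and the step of a number 10 percentage points higher from compound 2 to compound 3 (within the scatter) lies within the scatter. The step of a number 27 percentage points lower from compound 1 to compound 3 (beyond the scatter) lies beyond it.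

Compound 4 `Cc1ccc2ncc(S(=O)(=O)c3ccc(C)c(F)c3)c(N3CCC(C)CC3)c2c1` differs from compound 3 in one place: methyl in place of chloro on an aromatic carbon.

Among the compounds with values here, no measured step touches this place. The steps of a number 37 percentage points lower from compound 1 to compound 2 (beyond the scatter) and the other two all change the ring on the sulfonyl sulfur, not the shared core. There is therefore no basis for expecting a shift in either direction, and a step within the scatter is expected: a number 3 percentage points lower from compound 3 to compound 4 (within the scatter). For compound 4 the estimate is 65%, ranging from 40% to 85%.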

Compound 4, a percentage reported as inhibition, at one concentration (the size of the read-out at that concentration, not a potency): 91%
Estimate against measurement, compound 4: 26 percentage points below, outside the stated range (above it).
By their numbers in this assay, from the lowest: compounds 2 and 3 (each within the scatter of the next); then compounds 4 and 1 (each within the scatter of the next).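

Swapping chloro for methyl on the shared core gives a number 23 percentage points higher from compound 3 to compound 4 (beyond the scatter) in this assay, so this aromatic carbon, which no earlier step touched, clearly matters for the read-out. The two groups have the same heavy-atom count and neither has a hydrogen-bond donor or acceptor, so those counts do not separate them. Nothing measured here explains the change.

On these data alone, whether the same swap has a similar effect with the sulfonyl rings of compound 1 or compound 2 remains open. So does what a methoxy group, a nitrile or an amine would give at this position.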